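Adding Fluorine to the Phenoxy Ring of Compound 1

A few compounds are considered here, and "the series" means these few. Any claim that something is new, unique, unknown or untested is made for them only; others in the source may bear on it.

Measured compounds:
compound 1 `O=C1c2cc(COc3ccccc3)nn2CCN1c1ccc(F)cc1`, 79%
compound 2 `COc1ccc(N2CCn3nc(COc4ccccc4)cc3C2=O)cc1`, 58%

In a functional assay on HEK293 cells for positive allosteric modulation of metabotropic glutamate receptor 5 (Homo sapiens), read by calcium flux (a lower number here means a smaller maximal response, a higher number a larger maximal response), compound 1 gives 79%, the highest of the two numbers available. The nearest is compound 2, reached by a number 21 percentage points lower from compound 1 to compound 2 (beyond the scatter), a modest fall that lies beyond the usual scatter.

Compound 3 `O=C1c2cc(COc3ccc(F)cc3)nn2CCN1c1ccc(F)cc1` is the next candidate. It differs from compound 1 by fluoro in place of hydrogen on an aromatic carbon. Going by the values given here, the single measured step, a number 21 percentage points lower from compound 1 to compound 2 (beyond the scatter), concerns a different exchange of groups and so gives no direct guide to adding a fluoro where a hydrogen was. Among the compounds with values here, with nothing among the measured compounds speaking to this change, the reasonable expectation is a step of a number 3 percentage points lower from compound 1 to compound 3 (within the scatter), that is, no change beyond the scatter in this assay. Compound 3 is therefore estimated at 76%, with a range from 58% to 94%.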

Compound 3, largest response reached (Emax), in percent of the reference or control that the assay uses: 72%
Compound 3: middle estimate off by 4 percentage points, on the high side; the range from low to high includes it.
By their numbers in this assay, from the lowest: compound 2; then compounds 3 and 1 (each within the scatter of the next).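

In this assay the change from phenoxy to 4-fluorophenoxy gives a number 7 percentage points lower from compound 1 to compound 3 (within the scatter) and so cannot be told apart from no change at all. Going by these compounds alone, the earlier step, a number 21 percentage points lower from compound 1 to compound 2 (beyond the scatter) on swapping fluoro for methoxy, concerned the other aromatic ring, so this is the first reading from the phenoxy ring, and here a fluoro in place of hydrogen, para to a large group, keeps the maximal response within the usual scatter. No measurement at hand explains this outcome.

On these data alone, it remains open whether a different group at this carbon of the phenoxy ring, such as an amine or a carboxylic acid, would move the response beyond the scatter. As far as these compounds go, it is also open whether fluoro on another carbon of that ring would be tolerated in the same way.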